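Trifluoromethyl in place of hydrogen on the pendant phenyl

The source may report more compounds than this note shows. Statements on the series, on what has been measured and on what is new or still open speak of the compounds shown alone.

Compound 3 `COc1ccc(N/C=C\C(=O)c2nc(-c3ccccc3)n3ccccc23)cc1` gives 12800 nM in a functional assay on BT-474 cells (Homo sapiens) for cytotoxicity, read by MTT assay, with a stated time of 48 h (on this read-out lower numbers stand for stronger inhibition and higher numbers for weaker inhibition), the lowest of the two numbers shown, while compound 2 `COc1ccc(N/C=C\C(=O)c2nc(-c3ccc(OC)cc3)n3ccccc23)cc1` gives 15400 nM. Compound 1 `O=C(/C=C\Nc1ccc2cc[nH]c2c1)c1nc(-c2ccc(C(F)(F)F)cc2)n2ccccc12` gives only a limit, > 30000 nM, in this assay. The step of a 1.2-fold lower number from compound 2 to compound 3 (0.08 log units; within the scatter) is within the scatter. Compound 4 `COc1ccc(N/C=C\C(=O)c2nc(-c3ccc(C(F)(F)F)cc3)n3ccccc23)cc1` differs from compound 3 by trifluoromethyl in place of hydrogen on an aromatic carbon. Among the compounds with values here, the only measured step at this place, a 1.2-fold lower number from compound 2 to compound 3 (0.08 log units; within the scatter), barely moved the number, so a small change is expected here, with no clear direction beyond the scatter. Compound 4 is therefore estimated at 16000 nM in this assay, with a range from 7000 nM to 40000 nM, meaning a step of a 1.3-fold higher number from compound 3 to compound 4 (0.10 log units; within the scatter) that is expected to stay within the scatter.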

Compound 4, half-maximal inhibitory concentration: > 30000 nM
Compound 4 ended at the assay's limit (the forecaster's own chance of this, stated with the estimate: 25%); middle value at least 1.8-fold (0.27 log units) from the limit.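

The position on the pendant phenyl turns out not to be indifferent: trifluoromethyl in place of hydrogen gives an at least 2.3-fold higher number from compound 3 to compound 4 (0.36 log units; beyond the scatter) in this assay where the earlier swap of methoxy for hydrogen stayed within the scatter. Set against methoxy, the same group gives an at least 1.9-fold higher number from compound 2 to compound 4 (0.28 log units; that floor lies within the scatter) and that floor alone does not separate the two groups. Compound 4 gives a limit and not a number, and its step to compound 1, also a limit, cannot be read: the limit of > 30000 nM in this assay, at which 2 of the 4 values shown sit. From the compounds shown here alone, how far compound 4 lies past the limit stays open, as does what fluorine, an amine or a carboxylic acid would give at this position.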